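Methyl in Place of Chloro: One Expected Step

A few compounds are considered here, and "the series" means these few. Any claim that something is new, unique, unknown or untested is made for them only; others in the source may bear on it.

Measured compounds:
compound 1, `Cc1cc(C)nc(SCc2cc(=O)c3cc(Cl)ccc3o2)n1` — > 25000 nM
compound 2, `O=c1c(CSc2cc(=O)c3ccccc3s2)coc2ccccc12` — 3600 nM

Of the compounds shown here, two have been tested in a functional assay on SW480 cells (Homo sapiens) for cytotoxicity, read by MTT assay, with a stated time of 72 h; on this read-out lower numbers stand for stronger inhibition and higher numbers for weaker inhibition. Compound 1 returns only a limit of the assay, > 25000 nM, and no number. Compound 2 gives 3600 nM in this assay. The two share no single-point relationship, so their values are simply two readings side by side; what can be said of compound 1 is that it stands at the limit of > 25000 nM in this assay, at which 1 of the 2 values shown sits, with nothing below that mark to place it more precisely.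

Compound 3, `Cc1ccc2oc(CSc3nc(C)cc(C)n3)cc(=O)c2c1`, is the next compound to be measured in this assay. It differs from compound 1 in one place: methyl in place of chloro on an aromatic carbon. Since compound 1 is known only as a limit, the size of the step to compound 3 cannot be measured on the numbers shown; no step beyond the usual scatter is expected in this assay, and the most likely outcome is that compound 3 again returns a limit rather than a number. On that basis compound 3 is estimated at 30000 nM, within 8000 nM to 100000 nM, which corresponds to an expected step that the limit leaves unreadable from compound 1 to compound 3.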

Compound 3, half-maximal inhibitory concentration: > 25000 nM
Compound 3: no number, only a limit (the forecaster's own chance of this, stated with the estimate: 70%); the middle value does not contradict the limit.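

Going by these compounds alone, compound 1 and compound 3 are both known only as limits, so no step between them can be read. The compounds shown leave open whether methyl in place of chloro on an aromatic carbon makes any difference to the shared core, and how compound 2 relates to either compound through a single change.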